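Acetyl in place of (4-chlorophenyl)carbonyl: cytotoxicity notes

A few compounds are considered here, and "the series" means these few. Any claim that something is new, unique, unknown or untested is made for them only; others in the source may bear on it.

Compound 2 `O=C(Nc1cc(C(F)(F)F)cc(C(F)(F)F)c1)C1CCc2ccccc2N1C(=O)c1ccc(Cl)cc1` and compound 3 `O=C(Nc1ccccc1C(F)(F)F)C1CCc2ccccc2N1C(=O)c1ccc(Cl)cc1` differ in more than one place; the difference between their two cores is not broken down here. In a functional assay on ACHN cells (Homo sapiens) for cytotoxicity, read by sulforhodamine B assay, with a stated time of 72 h (a higher number here means a weaker inhibitor of growth, a lower number a stronger inhibitor of growth), compound 3 gives 824 nM and compound 2 gives 2570 nM. Compound 1 `CC(=O)N1c2ccccc2CCC1C(=O)Nc1cc(C(F)(F)F)cc(C(F)(F)F)c1` is compound 2 with methyl in place of 4-chlorophenyl on a carbonyl carbon. In this assay compound 1 reaches only a limit, > 70000 nM. That gives an at least 27-fold higher number from compound 2 to compound 1 (1.43 log units; beyond the scatter), a step whose size is bounded by the limit of > 70000 nM in this assay, at which 1 of the 3 values shown sits. Compound 4 `CC(=O)N1c2ccccc2CCC1C(=O)Nc1ccccc1C(F)(F)F` is compound 3 with the same change, (methyl in place of 4-chlorophenyl on a carbonyl carbon), at the same place. Within the data shown here, for compound 4 in this assay a step of the same kind is expected, resting on an at least 27-fold higher number from compound 2 to compound 1 (1.43 log units; beyond the scatter) as the only measured example, so the expected step is a 49-fold higher number from compound 3 to compound 4 (1.69 log units; beyond the scatter). Compound 4 is estimated at 40000 nM, between 12000 nM and 70000 nM, with a real chance that only a limit is reported.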

Compound 4, concentration for 50% growth inhibition: > 80000 nM
Compound 4 ended at the assay's limit (the forecaster's own chance of this, stated with the estimate: 45%); middle value at least 2.0-fold (0.30 log units) away from the limit.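

In this assay the change from (4-chlorophenyl)carbonyl to acetyl gives an at least 97-fold higher number from compound 3 to compound 4 (1.98 log units; beyond the scatter) on the core of compound 3, in the same direction as on the core of compound 1. For compound 4 the reading > 80000 nM is a limit of the assay and not a number. The direction of the change therefore carries from one core to the other, but its size on either core is not fixed: the same change on two cores in this assay, an at least 27-fold higher number (1.43 log units; beyond the scatter) from compound 2 to compound 1 and an at least 97-fold higher number (1.98 log units; beyond the scatter) from compound 3 to compound 4; the limit leaves it open whether they differ.

What the compounds shown leave open is whether the ring or its chlorine matters, as nothing lies between acetyl and (4-chlorophenyl)carbonyl. An unsubstituted phenyl, a longer chain or an amine on the same carbonyl carbon would address this.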